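The compounds below may be only part of what the source reports. "The series", "measured", "known", "first", "only" and "open" are said of these compounds alone.

In an assay on isolated protein for inhibition of lysosomal alpha-glucosidase (Homo sapiens), read by fluorescence, with stated times of 5 min and 45 min (a lower number here means a stronger inhibitor, a higher number a weaker inhibitor), compound 1 `O=C1Cc2cc(S(=O)(=O)N3CCNCC3)ccc2N1` gives "not active" (no number reported). Compound 2 `O=C1Cc2cc(S(=O)(=O)N3CCN(c4ccc(O)cc4)CC3)ccc2N1` gives 2370 nM and holds the lower of the two numbers recorded, with compound 3 `N#Cc1ccc(N2CCN(S(=O)(=O)c3ccc4c(c3)CC(=O)N4)CC2)cc1` nearest at 3260 nM. Within the data shown here, the one measured step between neighbours, a 1.4-fold higher number from compound 2 to compound 3 (0.14 log units; within the scatter), lies within the scatter, so cyano in place of hydroxy on that aromatic carbon left the number essentially unchanged. Compound 4 `O=C1Cc2cc(S(=O)(=O)N3CCN(c4ccc(F)cc4)CC3)ccc2N1` differs from compound 2 by fluoro in place of hydroxy on an aromatic carbon. Among the measured compounds shown here, this change swaps the same hydroxy for another small group on the same carbon, so the only step that bears on it suggests a move of no more than the scatter in this assay, in either direction. Compound 4 is therefore estimated at 2800 nM, with a range from 1200 nM to 6500 nM. That estimate means an expected step of a 1.2-fold higher number from compound 2 to compound 4 (0.07 log units; within the scatter), within the scatter.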

Compound 4, half-maximal inhibitory concentration: "not active" (no number reported)
Compound 4 has no reported number here; the estimate stays without a comparison.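

Compound 4 gives "not active" (no number reported), so no step from compound 2 to compound 4 can be read, and nothing shown bears on this result. The compounds shown leave open how far 4-fluorophenyl in place of 4-hydroxyphenyl shifts the number.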